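The source may hold more compounds than are shown below. What is called first, only, known or untested is meant among the compounds shown, and "the series" means these compounds.

Measured so far in a functional assay on RAW264.7 cells (Mus musculus) for inhibition, read by ELISA, with a stated time of 24 h; on this read-out higher numbers stand for weaker inhibition and lower numbers for stronger inhibition:
- compound 1, `COc1ccc(/C=C/CO[C@@H]2O[C@H](CO)[C@@H](O)[C@H](O[C@@H]3OC[C@](O)(COC(=O)/C=C/c4ccccc4)[C@H]3O)[C@H]2O)cc1O`, 27800 nM
- compound 2, `O=C1C[C@@H](c2ccc(O)c(O)c2)Oc2cc(O[C@@H]3O[C@H](CO)[C@@H](O)[C@H](O)[C@H]3O)cc(O)c21`, 41200 nM

Both numbers sit in the weak range. Compound 2 gives the higher of the two readings, but its gap to compound 1 is within the scatter of this assay, so the two cannot be told apart on these data; no ordering between them is claimed.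

Compound 3, `O=C(/C=C/c1ccccc1)OC[C@H]1O[C@@H](Oc2cc(O)c3c(c2)O[C@H](c2ccc(O)c(O)c2)CC3=O)[C@H](O)[C@@H](O)[C@@H]1O`, has not been measured. It differs from compound 2 in one place:

(2-phenylethenyl)carbonyl in place of hydrogen on an oxygen on a saturated carbon

Going by the values given here, the only comparison available is that compound 1, which also carries a (2-phenylethenyl)carbonyl ester on a sugar oxygen, sits in the same range as compound 2. That is not a step of this kind, so no measured step size can be borrowed. A small step toward a lower number is expected for the change from compound 2 to compound 3, of about a 1.6-fold lower number from compound 2 to compound 3 (0.22 log units; within the scatter), which is likely to stay within the scatter. The estimate for compound 3 in this assay is 25000 nM, with a range from 8000 nM to 70000 nM.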

Compound 3, half-maximal inhibitory concentration: 25100 nM
Estimate against measurement, compound 3: 1.0-fold (0.00 log units) below; low and high end bracket the measured number.
By their numbers in this assay, from the lowest: compounds 3, 1 and 2 (each within the scatter of the next).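

In this assay, going by these compounds alone, (2-phenylethenyl)carbonyl in place of hydrogen on an oxygen on a saturated carbon gives a 1.6-fold lower number from compound 2 to compound 3 (0.22 log units; within the scatter), the first change that can be read at a single place. At this position, therefore, hydroxymethyl to (((2-phenylethenyl)carbonyl)oxy)methyl brings in a whole aromatic ring and a double bond outside it, yet the reading of compound 3 cannot be told apart from that of compound 2. The data give no ground for explaining the size of this step.

Going by these compounds, whether an acetyl ester, a benzoyl ester or a saturated 3-phenylpropanoyl ester on this oxygen would read like compound 3 remains open, and so does the question of whether the double bond of the chain matters at all. On these data alone, it is equally open whether an amine or a carboxylic acid at this place, or the same (2-phenylethenyl)carbonyl ester on another sugar oxygen of the shared core, would give a step beyond the scatter.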